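A few compounds are considered here, and "the series" means these few. Any claim that something is new, unique, unknown or untested is made for them only; others in the source may bear on it.

Measured so far:
compound 1 `N#Cc1cnc(NCc2cnccc2C(F)(F)F)cc1N[C@H]1CC[C@@H](O)CC1` — 4500 nM
compound 2 `CO[C@H]1CC[C@@H](CNc2cc(NCc3cnccc3C(F)(F)F)ncc2C#N)CC1` — 5000 nM

In an assay on isolated protein for inhibition of protein kinase C delta type (Homo sapiens), read by TR-FRET, with a stated time of 2 h (on this read-out lower numbers stand for stronger inhibition and higher numbers for weaker inhibition), compound 1 gives 4500 nM. Within the data shown here, its only measured neighbour is compound 2, which differs by carrying (4-methoxycyclohexyl)methyl in place of 4-hydroxycyclohexyl on a nitrogen on an aromatic ring; a 1.1-fold higher number from compound 1 to compound 2 (0.05 log units; within the scatter), so the two compounds sit within the scatter of each other and neither stands apart.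

Compound 3 `CN(C)C(=O)[C@H]1CC[C@@H](Nc2cc(NCc3cnccc3C(F)(F)F)ncc2C#N)CC1` has not yet been measured. It differs from compound 1 in one place: dimethylcarbamoyl in place of hydroxy on a saturated ring carbon. Among the measured compounds shown here, the step from compound 1 to compound 2 is the only measured step, and it also reworked the six-membered non-aromatic ring of carbon only without moving the number beyond the scatter. On that basis the step from compound 1 to compound 3 is expected to stay within the scatter as well, no change at the digits printed from compound 1 to compound 3 (within the scatter). Compound 3 is therefore estimated at 4500 nM in this assay, with a range from 1500 nM to 13000 nM.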

Compound 3, half-maximal inhibitory concentration: 1800 nM
Compound 3: the middle estimate sits 2.5-fold (0.40 log units) above what was measured; the range from low to high includes it.
By their numbers in this assay, from the lowest: compound 3; then compounds 1 and 2 (each within the scatter of the next).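

In this assay, the saturated ring carbon three ring bonds from the ring atom that bears a large group responds to what it carries: dimethylcarbamoyl in place of hydroxy gives a 2.5-fold lower number from compound 1 to compound 3 (0.40 log units; beyond the scatter), a modest step and the first shown here to pass beyond the scatter. The hydrogen-bond donor of the hydroxy is lost and the group grows from one heavy atom to five, yet the number falls rather than rises. No measurement at hand accounts for this step.

This single change brings in the carbonyl, the methyl groups and the larger size together, and the compounds shown do not separate them. As far as these compounds go, it also stays open how a primary amide, a carboxylic acid or an amine on the same carbon would compare.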